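The source may report more compounds than this note shows. Statements on the series, on what has been measured and on what is new or still open speak of the compounds shown alone.

In a functional assay on HeLa cells (Homo sapiens) for cytotoxicity, read by MTT assay, with a stated time of 24 h (on this read-out lower numbers stand for stronger inhibition and higher numbers for weaker inhibition), compound 1 (`COc1ccc(/C=C2\CN(C)C/C(=C\c3ccccc3F)C2=O)cc1`) gives 23500 nM. Compound 2 (`COc1ccc(/C=C2\CN(C)C/C(=C\c3ccccc3F)C2=O)cc1OC`) gives 14400 nM, and the change is a 1.6-fold lower number from compound 1 to compound 2 (0.21 log units; within the scatter). Compound 3 (`COc1cc(/C=C2\CN(C)C/C(=C\c3ccccc3F)C2=O)cc(OC)c1OC`) gives 3220 nM, the lowest of the three, with a 4.5-fold lower number from compound 2 to compound 3 (0.65 log units; beyond the scatter). Compound 4 (`CN1C/C(=C\c2ccc(C(F)(F)F)cc2)C(=O)/C(=C/c2ccccc2F)C1`) has trifluoromethyl in place of methoxy on an aromatic carbon, para to a large group: trifluoromethyl in place of methoxy on an aromatic carbon. Both measured steps add methoxy in place of hydrogen, and none swaps methoxy for trifluoromethyl, so their guidance is indirect. The closer guide is a 1.6-fold lower number from compound 1 to compound 2 (0.21 log units; within the scatter), so no change beyond the scatter is expected in this assay. The expected change is a 1.5-fold lower number from compound 1 to compound 4 (0.17 log units; within the scatter). Compound 4 is estimated at 16000 nM, with an expected range of 5000 nM to 45000 nM.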

Compound 4, half-maximal inhibitory concentration: 6560 nM
Beside the measured number, compound 4's estimate is 2.4-fold (0.39 log units) above it; the measured number falls inside the stated range.
By their numbers in this assay, from the lowest: compound 3; then compound 4; then compounds 2 and 1 (each within the scatter of the next).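

In this assay, trifluoromethyl in place of methoxy on the aromatic carbon para to a large group gives a 3.6-fold lower number from compound 1 to compound 4 (0.55 log units; beyond the scatter). This position therefore responds beyond the scatter to a swap of group, whereas the earlier change on the same ring, a 1.6-fold lower number from compound 1 to compound 2 (0.21 log units; within the scatter), stayed within it. A lower number here also does not require methoxy at this position. Nothing measured here accounts for the shift.

Still open, from the compounds shown here alone, is whether a carboxylic acid or an amine at this position would follow trifluoromethyl or methoxy. Also open, going by these compounds, is whether the step reflects trifluoromethyl entering or methoxy leaving.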